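Aryl replacement on the carbonyl carbon of the shared core

A few compounds are considered here, and "the series" means these few. Any claim that something is new, unique, unknown or untested is made for them only; others in the source may bear on it.

Measured so far:
compound 1 `COc1cc(-c2cc(/C=C/C(=O)c3ccc(N)cc3)[nH]n2)cc(OC)c1OC` — -66%
compound 2 `COc1ccc(C(=O)/C=C/c2cc(-c3cc(OC)c(OC)c(OC)c3)n[nH]2)cc1` — -59%

In a functional assay on OVCAR-5 cells (Homo sapiens) for cytotoxicity, read by sulforhodamine B assay, with a stated time of 48 h, tested at 100 uM (on this read-out lower numbers stand for a stronger effect and higher numbers for a weaker effect at the one concentration tested), compound 1 gives -66% and compound 2 gives -59%. For the measured compounds named here, compound 2 holds the higher of the two numbers, but the only measured step, a number 7 percentage points higher from compound 1 to compound 2 (within the scatter), lies within the scatter, so the two compounds are not separable on this read-out.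

Compound 3 `COc1cc(-c2cc(/C=C/C(=O)c3ccc(F)c(F)c3)[nH]n2)cc(OC)c1OC` follows from compound 2 by 3,4-difluorophenyl in place of 4-methoxyphenyl on a carbonyl carbon. Going by the values given here, no measured step exchanges the whole aryl group on the carbonyl carbon; the single step on record, a number 7 percentage points higher from compound 1 to compound 2 (within the scatter), alters one substituent of that aryl group and stays within the scatter. That step offers no direction for the present change, so the expectation is no shift beyond the scatter, held with a wide range.

For compound 3 the estimate in this assay is -58%, between -85% and -25%. The step this estimate means is a number 1 percentage points higher from compound 2 to compound 3 (within the scatter), expected rather than known.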

Compound 3, a percentage reported as activity, at one concentration (the size of the read-out at that concentration, not a potency): -24%
Estimate against measurement, compound 3: 34 percentage points below; the measured number lies above the stated range.
By their numbers in this assay, from the lowest: compounds 1 and 2 (each within the scatter of the next); then compound 3.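

The aryl group on the carbonyl carbon is not a silent place in this series. In this assay 3,4-difluorophenyl in place of 4-methoxyphenyl gives a number 35 percentage points higher from compound 2 to compound 3 (beyond the scatter) and 3,4-difluorophenyl in place of 4-aminophenyl gives a number 42 percentage points higher from compound 1 to compound 3 (beyond the scatter) in the direction of a weaker effect, whereas the earlier change on this aryl group, a number 7 percentage points higher from compound 1 to compound 2 (within the scatter), did not separate its two compounds. No available evidence bears on the reason for this loss of effect.

The compounds shown leave open whether a phenyl group carrying a single fluorine, or an unsubstituted phenyl group, on the carbonyl carbon would read with compound 1 and compound 2 or with compound 3. From the compounds shown here alone, with one tested concentration, how these numbers relate to potency also remains open.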